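A few compounds are considered here, and "the series" means these few. Any claim that something is new, unique, unknown or untested is made for them only; others in the source may bear on it.

Working notes on the series.

The shared core of compound 1 `CO[C@@]12CCN(C)C[C@H]1[C@H](c1ccccc1)C(C#N)=C(N)O2` is kept throughout; the three measured compounds differ only in the substituent on the phenyl ring. In a functional assay on trachea (Cavia porcellus) (on this read-out higher numbers stand for weaker inhibition and lower numbers for stronger inhibition), compound 1 gives 19800 nM. Compound 2 `CO[C@@]12CCN(C)C[C@H]1[C@H](c1ccc(Br)cc1)C(C#N)=C(N)O2` carries bromo there and in this assay gives 7900 nM, a step of a 2.5-fold lower number from compound 1 to compound 2 (0.40 log units; beyond the scatter). Compound 3 `COc1ccc([C@@H]2C(C#N)=C(N)O[C@]3(OC)CCN(C)C[C@@H]23)cc1` carries methoxy at the same carbon and in this assay gives 23100 nM, which is the highest of the three numbers; against compound 1 the step is a 1.2-fold higher number from compound 1 to compound 3 (0.07 log units; within the scatter), against compound 2 it is a 2.9-fold higher number from compound 2 to compound 3 (0.47 log units; beyond the scatter).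

Compound 4 `CO[C@@]12CCN(C)C[C@H]1[C@H](c1ccc(-c3cccs3)cc1)C(C#N)=C(N)O2` is not yet measured. The change from compound 3 is thiophen-2-yl in place of methoxy on an aromatic carbon. For the measured compounds named here, the steps that bear on it are those at this same carbon: bromo gave a 2.5-fold lower number from compound 1 to compound 2 (0.40 log units; beyond the scatter), while methoxy gave a 1.2-fold higher number from compound 1 to compound 3 (0.07 log units; within the scatter). Going by the values given here, no measured compound carries an aromatic ring at this position, so the thiophen-2-yl step has no direct precedent; the two halo and methoxy steps only show that a substituent here can move the number modestly or not at all. An expected step of a 2.1-fold lower number from compound 3 to compound 4 (0.32 log units; beyond the scatter) is therefore taken, with a wide range. For compound 4 the estimate in this assay is 11000 nM, between 3000 nM and 40000 nM.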

Compound 4, half-maximal inhibitory concentration: 13800 nM
The estimate for compound 4 lay 1.3-fold (0.10 log units) below the measured number, and the stated range covers the measured number.
By their numbers in this assay, from the lowest: compounds 2, 4, 1 and 3 (each within the scatter of the next, the first and the last beyond it).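

For the compounds shown here, the thiophen-2-yl step is the first at this carbon to bring in a ring, and it adds more heavy atoms than any earlier substituent, yet in this assay all three of its steps stay small: a 1.4-fold lower number from compound 1 to compound 4 (0.16 log units; within the scatter), a 1.7-fold lower number from compound 3 to compound 4 (0.22 log units; within the scatter) and a 1.7-fold higher number from compound 2 to compound 4 (0.24 log units; within the scatter). Compound 4 therefore cannot be separated from compound 1, compound 2 or compound 3, even though compound 2 and compound 3 are separated from each other, with a 2.9-fold higher number from compound 2 to compound 3 (0.47 log units; beyond the scatter), so a five-membered aromatic ring at this carbon gives a number that the earlier substituents had already spanned. Nothing measured on these compounds accounts for the size of these steps.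

The compounds shown leave open how an amine or a carboxylic acid at this carbon would read in this assay, and whether a phenyl ring or a longer alkyl chain there would stay within the same span. They also leave open whether a change to the shared core, such as another group in place of the methyl on nitrogen, would move the number further than any substituent on the phenyl ring has so far.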